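Swapping the Halogenated Ring on the Piperazine Nitrogen

A few compounds are considered here, and "the series" means these few. Any claim that something is new, unique, unknown or untested is made for them only; others in the source may bear on it.

Measured so far:
Compound 1, `CC(C(=O)N1CCN(c2ccccc2C(F)(F)F)CC1)N1C(=O)CCC1=O`: 100%
Compound 2, `CCC(C(=O)N1CCN(c2ccccc2F)CC1)N1C(=O)CCC1=O`: 100%
Compound 3, `COc1cccc(N2CCN(C(=O)C(C)N3C(=O)CCC3=O)CC2)c1`: 75%

All three were tested in a functional assay on the whole organism (strain Swiss) with Mus musculus as the target, in the maximal electroshock model, with a stated time of 0.25 h, at a dose of 300 mg/kg by the intraperitoneal route; a lower number here means a weaker effect, a higher number a stronger effect of the compound at the dose given. Compound 2 stands level with compound 1 at the digits reported; together they give the highest numbers of the three, and the gap between them lies within the usual scatter. Compound 3 gives a clearly lower number, a difference that goes beyond the scatter, so compound 2 sits at the top of this small set.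

Compound 4, `CCC(C(=O)N1CCN(c2ccc(Cl)cc2)CC1)N1C(=O)CCC1=O`, has not yet been measured. It differs from compound 2 in one place: 4-chlorophenyl in place of 2-fluorophenyl on an amine nitrogen in a ring. Going by the values given here, since no measured pair shows this exact change, the size of the step can only be guessed. A full effect at this dose leaves little room upward, so the expected step of a number 10 percentage points lower from compound 2 to compound 4 (within the scatter) is small, a modest drop at most, probably not beyond the scatter. Compound 4 is therefore expected to give about 90%, within a range from 70% to 100%.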

Compound 4, a percentage reported as activity, at one dose (the size of the read-out at that dose, not a potency): 0%
Beside the measured number, compound 4's estimate is 90 percentage points above it; the whole stated range lies above it.
By their numbers in this assay, from the lowest: compound 4; then compound 3; then compounds 1 and 2 (each within the scatter of the next).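

In this assay, 4-chlorophenyl in place of 2-fluorophenyl on the amine nitrogen in the ring gives a number 100 percentage points lower from compound 2 to compound 4 (beyond the scatter), so this one exchange can take the read-out at this dose from its full level to nothing. The earlier compounds shown here gave no sign of such sensitivity at this position. The two groups have the same number of heavy atoms, the same aromatic ring, no hydrogen-bond donors or acceptors and no net charge, so these counts do not separate the two results, and no measurement at hand accounts for the difference.

The halogen and its place on the ring change together here, so the compounds shown cannot separate the two; 4-fluorophenyl or 2-chlorophenyl on the same nitrogen would do so. As far as these compounds go, how a plain phenyl group there would compare also remains open.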